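Turning the Amide Around on a Shared Core

The compounds below may be only part of what the source reports. "The series", "measured", "known", "first", "only" and "open" are said of these compounds alone.

Of the compounds shown here, three built on one shared core have been tested in an assay on CHO-K1 cells for displacement of a labelled ligand from prostaglandin E2 receptor EP1 subtype (Homo sapiens); a lower number here means a stronger inhibitor, a higher number a weaker inhibitor. Compound 1 `Cc1cc(C(=O)O)nn1Cc1cc(Br)ccc1OCc1ccccc1` gives 6.31 nM, compound 2 `Cc1cc(C(=O)NCc2cccnc2)nn1Cc1cc(Cl)ccc1OCc1ccccc1` gives 50.1 nM, and compound 3 `Cc1cc(C(=O)NN2CCCCC2)nn1Cc1cc(Cl)ccc1OCC(C)C` gives 200 nM. Among these three numbers compound 2 stands second highest: compound 1 sits well below it, beyond the scatter, and compound 3 sits above it, also beyond the scatter. So compound 2 is neither the strongest nor the weakest of the measured set.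

Compound 4 `Cc1cc(NC(=O)c2c(F)cccc2F)nn1Cc1cc(Cl)ccc1OCc1ccccc1` has not yet been measured. It differs from compound 2 in one place: ((2,6-difluorophenyl)carbonyl)amino in place of ((pyridin-3-yl)methyl)carbamoyl on an aromatic carbon. The group that leaves and the group that enters each contain one six-membered aromatic ring and one double bond outside aromatic rings, but the ring of the entering group is built of carbon only and carries two fluorine atoms, and the attachment to the core is turned around, so that the nitrogen now sits on the ring carbon.

Going by the values given here, no measured pair shows this exact change, so the expectation rests on loose grounds. The change is expected to give a modest step toward a higher number, close to the scatter, as a 2.0-fold higher number from compound 2 to compound 4 (0.30 log units; within the scatter). Compound 4 is estimated to give 100 nM in this assay, within a range from 20 nM to 500 nM.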

Compound 4, half-maximal inhibitory concentration: 12.6 nM
The estimate for compound 4 lay 7.9-fold (0.90 log units) above the measured number; the measured number lies below the stated range.
By their numbers in this assay, from the lowest: compounds 1 and 4 (each within the scatter of the next); then compound 2; then compound 3.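

In this assay, going by these compounds alone, the one-place change gives a 4.0-fold lower number from compound 2 to compound 4 (0.60 log units; beyond the scatter), the first step in this set that can be read between two compounds differing in a single place. It shows that this aromatic carbon, next to the ring nitrogen, can carry an attachment turned around so that the nitrogen sits on the ring carbon, together with a carbon-only ring bearing two fluorine atoms, and that the number falls rather than rises with this swap. The step bundles these differences together and cannot assign the drop to any one of them, and nothing measured here offers an explanation for it.

A group such as ((2,6-difluorophenyl)methyl)carbamoyl at this position, which would keep the attachment direction of compound 2 while carrying the ring of compound 4, would help separate the effect of turning the amide from the effect of changing the ring. Likewise, (phenylcarbonyl)amino, the same turned group without its two fluorine atoms, leaves open what those atoms contribute to the number.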